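This account rests on a few compounds, and the source may have more. Where it says the series, first, only, none or still open, it means among the compounds named here.

Two compounds have been measured in a functional assay on mitochondria (Cricetulus griseus) for inhibition of Monoamine oxidase (Homo sapiens), tested at 0.9 uM; on this read-out higher numbers stand for a stronger effect at the one concentration tested and lower numbers for a weaker effect:
compound 1 `O=c1c(-c2ccc(O)cc2)coc2cc(OCCCCCCBr)ccc12` gives 71.2%;
compound 2 `O=c1c(-c2ccc(O)cc2)coc2cc(OCCCCBr)ccc12` gives 55.3%.

Compound 2 thus holds the lower of the two numbers. Compound 3 `O=C(O)CCCCCCCCCOc1ccc2c(=O)c(-c3ccc(O)cc3)coc2c1` differs from it in one place: 5-carboxypentyl in place of bromo on a saturated chain carbon, four bonds along the chain from an oxygen on an aromatic ring. Among the compounds with values here, the only measured step, a number 15.9 percentage points lower from compound 1 to compound 2 (beyond the scatter), concerns the same chain and went with the shorter chain to the lower number; compound 3 carries the longer chain of the pair. A modest rise is therefore expected, a number 6.7 percentage points higher from compound 2 to compound 3 (within the scatter), although the entering carboxyl group has no measured counterpart among these compounds. Compound 3 is estimated at 62%, with a range from 38% to 82%.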

Compound 3, a percentage reported as inhibition, at one concentration (the size of the read-out at that concentration, not a potency): 85.1%
Estimate against measurement, compound 3: 23.1 percentage points below; the whole stated range lies below it.
By their numbers in this assay, from the lowest: compound 2; then compound 1; then compound 3.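

The earlier compounds shown here carried only a bromo group at the chain end, and the carboxyl-ended chain now gives the highest number of the three in this assay. The change brings a number 29.8 percentage points higher from compound 2 to compound 3 (beyond the scatter), and it also goes beyond the longer bromo chain, with a number 13.9 percentage points higher from compound 1 to compound 3 (beyond the scatter). Nothing available explains this rise.

Chain length and end group change together here, so their shares stay open. A bromo chain or an amine-ended chain of the same length as in compound 3 would separate them.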